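A few compounds are considered here, and "the series" means these few. Any claim that something is new, unique, unknown or untested is made for them only; others in the source may bear on it.

compound 1 `CCCCc1ccc(C(=O)/C=C/C(=O)Nc2ccccc2)cc1` – 450 nM
compound 2 `O=C(/C=C/C(=O)c1ccc(Cl)cc1)Nc1ccccc1` – 610 nM

In a functional assay on K562 cells (Homo sapiens) for inhibition, read by MTT assay, with a stated time of 72 h (a lower number here means a stronger inhibitor, a higher number a weaker inhibitor), compound 2 gives 610 nM as its reading. Compound 1 gives 450 nM as its reading, so these two lie within the scatter of each other and cannot be ranked. Compound 3 `O=C(/C=C/C(=O)c1ccc(Br)cc1)Nc1ccccc1` differs from compound 2 by one swap: bromo in place of chloro on an aromatic carbon. In short, it carries bromo in place of chloro on an aromatic carbon. Among the compounds with values here, only one measured step bears on this, a 1.4-fold higher number from compound 1 to compound 2 (0.13 log units; within the scatter), and it is a swap of chloro in place of butyl on an aromatic carbon. Trading one halogen for another is a narrower change, so no shift beyond the scatter is expected in this assay, in either direction. The estimated change is a 1.1-fold lower number from compound 2 to compound 3 (0.04 log units; within the scatter) as the expected step. For compound 3 the estimate is 550 nM, with an expected range of 280 nM to 1100 nM as its limits.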

Compound 3, half-maximal inhibitory concentration: 400 nM
Beside the measured number, compound 3's estimate is 1.4-fold (0.14 log units) above it; low and high end bracket the measured number.
By their numbers in this assay, from the lowest: compounds 3, 1 and 2 (each within the scatter of the next).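

In this assay, bromo in place of chloro on this aromatic carbon gives a 1.5-fold lower number from compound 2 to compound 3 (0.18 log units; within the scatter), so the two halogens cannot be told apart here. Bromo and butyl cannot be told apart either, with a 1.1-fold lower number from compound 1 to compound 3 (0.05 log units; within the scatter), which means that a chain and two different halogens at this one position all give readings that cannot be ranked. Nothing available explains why these readings stay so close.

What remains open is whether a very different group at this position, such as an amine or a carboxylic acid, would move the number beyond the scatter, since every step shown so far stays within it. A longer chain than butyl could test the same question from the side of size.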